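The source may hold more compounds than are shown below. What is called first, only, known or untested is meant among the compounds shown, and "the series" means these compounds.

Measured so far: compound 1 `OCC#CCSc1cnc2ccccc2c1[Se]CC#CCBr` gives 2.8 ug/mL in a functional assay on SW707 cells (Homo sapiens) for cytotoxicity, read by sulforhodamine B assay, with a stated time of 72 h; on this read-out lower numbers stand for stronger inhibition and higher numbers for weaker inhibition; compound 2 `OCC#CCSc1cnc2ccccc2c1SCC#CCBr` gives 36.2 ug/mL.

Going by the values given here, compound 2 holds the higher number of the two; the one measured step, a 13-fold higher number from compound 1 to compound 2 (1.11 log units; beyond the scatter), leads to it. Compound 3 `OCC#CCSc1cnc2ccccc2c1[Se]CC#CCO` is not yet measured. Its change from compound 2: a group of 6 heavy atoms (4 carbon, 1 oxygen, 1 selenium; no ring) in place of a group of 6 heavy atoms (4 carbon, 1 sulfur, 1 bromine; no ring), on an aromatic carbon. Among the compounds with values here, that step bears on it only in part: selenium returns in place of sulfur, the direction opposite to the measured step, while the bromine-for-hydroxyl part has no measured counterpart. A fall beyond the scatter is therefore expected, a 7.2-fold lower number from compound 2 to compound 3 (0.86 log units; beyond the scatter). Compound 3 is estimated at 5 ug/mL, range 1.5 ug/mL to 20 ug/mL.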

Compound 3, concentration for 50% inhibition: 26.6 ug/mL
Estimate against measurement, compound 3: 5.3-fold (0.73 log units) below, and the stated range ends below it.
By their numbers in this assay, from the lowest: compound 1; then compounds 3 and 2 (each within the scatter of the next).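

With selenium held fixed, hydroxy in place of bromo at the chain end gives a 9.5-fold higher number from compound 1 to compound 3 (0.98 log units; beyond the scatter) in this assay, so this end of the group on the aromatic carbon also matters. The double change gives a 1.4-fold lower number from compound 2 to compound 3 (0.13 log units; within the scatter), so selenium with the hydroxy end does not recover the number of compound 1. Nothing available accounts for either step.

Open: whether a chloro or an amine at this chain end would keep the number of compound 1, and whether selenium and sulfur differ as much with a hydroxy end.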